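Fluoro for chloro on a charged-chain anilide series

The source may report more compounds than this note shows. Statements on the series, on what has been measured and on what is new or still open speak of the compounds shown alone.

Compound 1 `CN(C)c1ccc2c(=O)c(C(=O)Nc3cc(F)cc(F)c3)cn(-c3ccc(OCCCCCCC[N+]45CCN(CC4)CC5)cc3F)c2n1`: 42.4%
Compound 2 `CN(C)c1ccc2c(=O)c(C(=O)Nc3cc(F)cc(F)c3)cn(-c3ccc(OCCCCCCC[N+]4(C)CCCCC4)cc3F)c2n1`: "not active" (no number reported)
Compound 3 `CC[N+]1(CCCCCCCOc2ccc(-n3cc(C(=O)Nc4cc(F)cc(F)c4)c(=O)c4ccc(N(C)C)nc43)c(Cl)c2)CCCCC1`: "not active" (no number reported)

Three compounds share one core and differ in the charged group at the end of the chain and in the halogen on the ring that carries the chain. In an assay on LX2 cells for inhibition of COL1A1 promoter (Homo sapiens), read by a luciferase reporter, with a stated time of 24 h, tested at 50 uM (on this read-out higher numbers stand for a stronger effect at the one concentration tested and lower numbers for a weaker effect), compound 1 gives 42.4%. Compound 2, in this assay, is reported as "not active" (no number reported) with no number attached. Compound 3 stands in the same position: in this assay it is reported as "not active" (no number reported), with no single number, and it is one of two entries in this set without a number. Among the compounds with values here, no step between measured compounds that differ in one place is available, so nothing in this set shows how a single change shifts the read-out.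

Compound 4 `CC[N+]1(CCCCCCCOc2ccc(-n3cc(C(=O)Nc4cc(F)cc(F)c4)c(=O)c4ccc(N(C)C)nc43)c(F)c2)CCCCC1` is the next compound. It differs from compound 3 by fluoro in place of chloro on an aromatic carbon; the change sits on an aromatic carbon of a six-membered aromatic ring of carbon only, ortho to a large group and meta to a large group. Within the data shown here, since compound 3 has no number, no size of step can be computed; compound 2 carries fluoro at this place and is also without a number, and only compound 1, with a different charged group, gives a value. Compound 4 is therefore expected to give a weak read-out, estimated at 12%, within a range from 0% to 35%, with a fair chance that only an inactivity call and no number is reported.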

Compound 4, a percentage reported as inhibition, at one concentration (the size of the read-out at that concentration, not a potency): "not active" (no number reported)
Compound 4 has no reported number here, so the estimate cannot be set against anything.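

In this assay, within the data shown here, compound 3 is reported as "not active" (no number reported) and compound 4 as "not active" (no number reported) with no figure on either side, so no step from chloro to fluoro can be read between them. Nothing shown here offers an explanation for this result. The compounds shown leave open whether this halogen swap affects the read-out at all.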